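Restoring the alpha amine on a shortened amide partner

The source may hold more compounds than are shown below. What is called first, only, known or untested is meant among the compounds shown, and "the series" means these compounds.

Compound 1 `CCCCCCCCCCCC(=O)N[C@H](CCC(=O)NC(CCCC(N)C(=O)O)C(=O)O)C(=O)O` gives 0.027 nM in a functional assay on HEK293 cells for agonist activity at Nucleotide-binding oligomerization domain-containing protein 1 (Homo sapiens), read by spectrophotometry; on this read-out lower numbers stand for an effect already at smaller amounts and higher numbers for an effect only at larger amounts of compound.
Compound 2 `CCCCCCCCCCCC(=O)N[C@H](CCC(=O)NC(CCCC(NC(=N)N)C(=O)O)C(=O)O)C(=O)O` gives 0.622 nM in this assay.
Compound 3 `CCCCCCCCCCCC(=O)N[C@H](CCC(=O)NC(CCCCC(=O)O)C(=O)O)C(=O)O` gives > 100 nM in this assay.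

In this assay compound 3 gives only a limit and no number; it sits at the limit of > 100 nM in this assay, at which 1 of the 3 values shown sits. Compound 4 `CCCCCCCCCCCC(=O)N[C@H](CCC(=O)NCCCC[C@@H](N)C(=O)O)C(=O)O` differs from compound 3 by a group of 9 heavy atoms (6 carbon, 1 nitrogen, 2 oxygen; no ring) in place of a group of 11 heavy atoms (7 carbon, 4 oxygen; no ring), on an amide-type nitrogen, so an amine returns while a carboxylic acid is lost. For the measured compounds named here, the step of an at least 3700-fold higher number from compound 1 to compound 3 (3.56 log units; beyond the scatter) shows that removing this amine carries a heavy cost, and an at least 160-fold higher number from compound 2 to compound 3 (2.20 log units; beyond the scatter) points the same way; no measured step covers the loss of the acid. Compound 4 is therefore expected to show a far lower number, an at least 5.0-fold lower number from compound 3 to compound 4 (0.69 log units; beyond the scatter). The estimate for compound 4 in this assay is 20 nM, within 1 nM to 500 nM.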

Compound 4, half-maximal effective concentration: 0.37 nM
The estimate for compound 4 lay 54-fold (1.73 log units) above the measured number; the whole stated range lies above it.
By their numbers in this assay, from the lowest: compound 1; then compounds 4 and 2 (each within the scatter of the next). At a limit, above all of these: compound 3.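

The exchange on the amide-type nitrogen gives an at least 270-fold lower number from compound 3 to compound 4 (2.43 log units; beyond the scatter). Compound 1, compound 2 and compound 3 all keep the group that leaves here, so they showed the weight of the amine only with that extra carboxylic acid in place; compound 4 shows that a low number in this assay does not depend on it. This step is only a bound, set by a limit for compound 3: the limit of > 100 nM in this assay, at which 1 of the 4 values shown sits.

Going by these compounds, whether a longer chain bearing the amine, or an ester in place of the remaining carboxylic acid, would keep the number low stays open.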